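A few compounds are considered here, and "the series" means these few. Any claim that something is new, unique, unknown or untested is made for them only; others in the source may bear on it.

Values in a functional assay on DU-145 cells (Homo sapiens) for inhibition, read by trypan blue exclusion, with a stated time of 96 h; a lower number here means a stronger inhibitor of growth, a higher number a weaker inhibitor of growth:
compound 1 `COc1cc(OC)c(/C=C(/SCc2ccc(Cl)cc2)C(=O)c2ccc(Br)cc2)c(OC)c1`: 1000 nM
compound 2 `COc1cc(OC)c(/C=C(\C(=O)c2ccc(Br)cc2)S(=O)(=O)Cc2ccc(Cl)cc2)c(OC)c1`: 25000 nM
compound 3 `COc1cc(OC)c(/C=C(/Sc2ccc(C)cc2)C(=O)c2ccc(Br)cc2)c(OC)c1`: > 100000 nM, a limit of the assay

Compound 2 holds the higher of the two numerical values, and the step of a 25-fold higher number from compound 1 to compound 2 (1.40 log units; beyond the scatter) separates it clearly from its nearest neighbour.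

Compound 4 `COc1cc(OC)c(/C=C(\C(=O)c2ccc([N+](=O)[O-])cc2)S(=O)(=O)Cc2ccc(Cl)cc2)c(OC)c1` differs from compound 2 in one place: nitro in place of bromo on an aromatic carbon. This is nitro in place of bromo on an aromatic carbon, para to a large group.

Within the data shown here, no measured step touches that position, since compound 1, compound 2 and compound 3 all carry the 4-bromophenyl group. The steps of a 25-fold higher number from compound 1 to compound 2 (1.40 log units; beyond the scatter), an at least 100-fold higher number from compound 1 to compound 3 (2.00 log units; beyond the scatter) and an at least 4.0-fold higher number from compound 2 to compound 3 (0.60 log units; beyond the scatter) all concern the group on sulfur. They show that the series can move widely, but they give no direction for this change.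

With compound 2 at 25000 nM as the anchor, the expected result is a 1.3-fold lower number from compound 2 to compound 4 (0.10 log units; within the scatter), which means no shift beyond the scatter. For compound 4 the estimated value is 20000 nM, with an expected range of 4000 nM to 80000 nM.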

Compound 4, concentration for 50% growth inhibition: 10000 nM
For compound 4 the middle estimate is 2.0-fold (0.30 log units) above the measured one, and the stated range covers the measured number.
By their numbers in this assay, from the lowest: compound 1; then compound 4; then compound 2. At a limit, above all of these: compound 3.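

In this assay, the change from 4-bromophenyl to 4-nitrophenyl gives a 2.5-fold lower number from compound 2 to compound 4 (0.40 log units; beyond the scatter), so this position on the (4-chlorobenzyl)sulfonyl compounds does respond to substitution, and nitro is accepted there without any loss. The step is modest beside a 25-fold higher number from compound 1 to compound 2 (1.40 log units; beyond the scatter), the change at sulfur, so in the compounds shown the sulfur oxidation state moves the number further than this aromatic substituent does. Nothing measured here accounts for the direction of the step.

Going by these compounds, the nitro group appears only with the (4-chlorobenzyl)sulfonyl group, so it remains open whether the same step would hold on the (4-chlorobenzyl)sulfanyl compound 1. Also open, on these data alone, is how an amine or a carboxylic acid on that aromatic carbon would read in this assay.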